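The compounds below may be only part of what the source reports. "The series", "measured", "known", "first", "only" and "open" are said of these compounds alone.

Measured so far:
Compound 1, `CC[C@H]1OC(=O)[C@H](C)[C@@H](O[C@H]2C[C@@](C)(OC)[C@@H](OCCCNC(C)=O)[C@H](C)O2)[C@H](C)[C@@H](O[C@@H]2O[C@H](C)C[C@H](N(C)C)[C@H]2O)[C@](C)(O)C[C@@H](C)CN(C)[C@H](C)[C@@H](O)[C@]1(C)O`, gives 2.06 in a physicochemical assay for lipophilicity, read by HPLC, measured as chromatographic lipophilicity, at pH 7.4; a higher number here means a more lipophilic compound, a lower number a more polar compound.
Compound 2, `CCC(=O)NCCCO[C@H]1[C@H](C)O[C@@H](O[C@H]2[C@H](C)[C@@H](O[C@@H]3O[C@H](C)C[C@H](N(C)C)[C@H]3O)[C@](C)(O)C[C@@H](C)CN(C)[C@H](C)[C@@H](O)[C@](C)(O)[C@@H](CC)OC(=O)[C@@H]2C)C[C@@]1(C)OC`, gives 2.54 in this assay.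
Compound 3, `CC[C@H]1OC(=O)[C@H](C)[C@@H](O[C@H]2C[C@@](C)(OC)[C@@H](O)[C@H](C)O2)[C@H](C)[C@@H](O[C@@H]2O[C@H](C)C[C@H](N(C)C)[C@H]2O)[C@](C)(O)C[C@@H](C)CN(C)[C@H](C)[C@@H](OCCCNC(C)=O)[C@]1(C)O`, gives 2.41 in this assay.

Compound 1 and compound 2 differ by methyl in place of hydrogen on a saturated chain carbon bound to a carbonyl carbon, and this change produced a number 0.48 log units higher from compound 1 to compound 2 (beyond the scatter). Compound 3 carries the same atoms as compound 1 joined differently; the difference between the two cores is not broken down here. The values of compound 3 and compound 2 lie within the scatter of each other, while the value of compound 3 stands beyond the scatter from that of compound 1.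

Compound 4, `CCC(=O)NCCCO[C@@H]1[C@@H](C)N(C)C[C@H](C)C[C@@](C)(O)[C@H](O[C@@H]2O[C@H](C)C[C@H](N(C)C)[C@H]2O)[C@@H](C)[C@H](O[C@H]2C[C@@](C)(OC)[C@@H](O)[C@H](C)O2)[C@@H](C)C(=O)O[C@H](CC)[C@@]1(C)O`, differs from compound 3 by methyl in place of hydrogen on a saturated chain carbon bound to a carbonyl carbon, the same change seen between compound 1 and compound 2. Compound 4 is therefore expected to give about 2.89 in this assay, between 2.55 and 3.25. The expected step, a number 0.48 log units higher from compound 3 to compound 4 (beyond the scatter), rests on the measured step of a number 0.48 log units higher from compound 1 to compound 2 (beyond the scatter).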

Compound 4, distribution coefficient: 2.74
The estimate for compound 4 lay 0.15 log units above the measured number; the measured number falls inside the stated range.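

On the core of compound 3, methyl in place of hydrogen on a saturated chain carbon bound to a carbonyl carbon, which turns acetamido into propanoylamino, gave a number 0.33 log units higher from compound 3 to compound 4 (beyond the scatter) in this assay, the same direction as a number 0.48 log units higher from compound 1 to compound 2 (beyond the scatter) on the core of compound 1. This shows that the change carried over between these two cores in direction, but with one pair on each core it does not show that it would do so on any other core or that its size is fixed. Nothing available explains either step.

The compounds shown leave open how a longer chain, such as butanoyl in place of propanoyl, would read on either core. They also leave open what a carboxylic acid or an amine in place of the amide would give.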